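Straightening the isobutyl chain of compound 3

The source may report more compounds than this note shows. Statements on the series, on what has been measured and on what is new or still open speak of the compounds shown alone.

Of the compounds shown here, three sharing one core have been measured in a functional assay on A549 cells (Homo sapiens) for antiproliferative activity, read by MTT assay; a lower number here means a stronger inhibitor, a higher number a weaker inhibitor. Compound 1 `COC(=O)N1CCCc2cc(S(=O)(=O)N3CC(c4ccccc4)NC3=O)ccc21` gives 1150 nM, and compound 2 `CCCOC(=O)N1CCCc2cc(S(=O)(=O)N3CC(c4ccccc4)NC3=O)ccc21` gives 1030 nM. The step linking them is small, a 1.1-fold lower number from compound 1 to compound 2 (0.05 log units; within the scatter). Compound 3 `CC(C)COC(=O)N1CCCc2cc(S(=O)(=O)N3CC(c4ccccc4)NC3=O)ccc21` reads > 20000 nM, which is a limit of the assay and not a number. The other two steps are large, an at least 17-fold higher number from compound 1 to compound 3 (1.24 log units; beyond the scatter) and an at least 19-fold higher number from compound 2 to compound 3 (1.28 log units; beyond the scatter).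

Compound 4 `CCCCOC(=O)N1CCCc2cc(S(=O)(=O)N3CC(c4ccccc4)NC3=O)ccc21` has the same atoms as compound 3, joined differently: propyl in place of isopropyl on a saturated chain carbon bound to an oxygen next to a carbonyl group. Isobutyl thus gives way to butyl, which lacks the methyl added in the last of those steps. The longer chain of compound 2, at 1030 nM, suggests that chain length alone need not shift the number. A large step toward a lower number is therefore expected, an at least 10-fold lower number from compound 3 to compound 4 (1.00 log units; beyond the scatter). No straight butyl chain has yet been measured, so the range stays wide on the upper side. Compound 4 is expected at 2000 nM, with an estimated range from 600 nM to 12000 nM.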

Compound 4, half-maximal inhibitory concentration: > 20000 nM
Compound 4: a limit, no number (the forecaster's own chance of this, stated with the estimate: 15%); middle value at least 10-fold (1.00 log units) away from the limit.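

Compound 4, like compound 3, stands at a limit of this assay and not at a number, so exchanging the isobutyl chain for butyl brings no readable return. Methyl in place of hydrogen on a saturated chain carbon, three bonds along the chain from an oxygen next to a carbonyl group, gives an at least 19-fold higher number from compound 2 to compound 4 (1.28 log units; beyond the scatter), and the full propyl change gives an at least 17-fold higher number from compound 1 to compound 4 (1.24 log units; beyond the scatter), so among these compounds the large loss does not depend on a branch. The steps between compound 3 and compound 4 cannot be read, because both stand at the same limit: the limit of > 20000 nM in this assay, at which 2 of the 4 values shown sit.

On these data alone, how far compound 3 and compound 4 lie beyond that limit remains open. So does whether a longer chain such as pentyl, or a butyl chain ending in an amine or a hydroxyl group, would stay at the limit or return toward compound 2.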